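Swapping a pentyl chain for a 2-chlorophenyl ring

The source may report more compounds than this note shows. Statements on the series, on what has been measured and on what is new or still open speak of the compounds shown alone.

Measured so far in a functional assay on MCF7 cells (Homo sapiens) for cytotoxicity, read by MTT assay, with a stated time of 72 h; on this read-out lower numbers stand for stronger inhibition and higher numbers for weaker inhibition:
compound 1 `CC(C)(C)c1nnc2nnc(N3CCCC3)nn12` gives 55000 nM
compound 2 `CCCCCc1nnc2nnc(N3CCCC3)nn12` gives 42900 nM

The number for compound 2 is the lower of the two, but the gap to compound 1 lies within the usual scatter, so on this read-out the two compounds cannot be told apart. Compound 3 `Clc1ccccc1-c1nnc2nnc(N3CCCC3)nn12` has not yet been measured. It differs from compound 2 in one place: 2-chlorophenyl in place of pentyl on an aromatic carbon. Among the compounds with values here, the only measured step, a 1.3-fold lower number from compound 1 to compound 2 (0.11 log units; within the scatter), exchanges one chain for another and says little about placing an aromatic ring at this position, so the change to compound 3 is largely uncharted. Compound 3 is therefore expected to land near compound 2, with a step of a 1.4-fold lower number from compound 2 to compound 3 (0.16 log units; within the scatter) that is small and uncertain in direction. The estimate for compound 3 in this assay is 30000 nM, with a likely range from 8000 nM to 100000 nM.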

Compound 3, half-maximal inhibitory concentration: 29600 nM
Estimate against measurement, compound 3: 1.0-fold (0.01 log units) above; low and high end bracket the measured number.
By their numbers in this assay, from the lowest: compounds 3, 2 and 1 (each within the scatter of the next).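

The first aromatic ring at this position, 2-chlorophenyl, gives no result that can be separated from those of the two chains in this assay: the data show a 1.4-fold lower number from compound 2 to compound 3 (0.16 log units; within the scatter) and a 1.9-fold lower number from compound 1 to compound 3 (0.27 log units; within the scatter). So pentyl, tert-butyl and 2-chlorophenyl, which differ in size and in having a ring, cannot be told apart here on this read-out, and exchanging a chain for this ring brings no clear gain or loss. Nothing available offers a reason for this flat result.

Still open, going by these compounds, is whether any group on this carbon can move the number beyond the scatter, such as an unsubstituted phenyl, a 4-chlorophenyl, an amine or a carboxylic acid. On these data alone, all three compounds also share the remainder of the structure, so the effect of changing anything else remains unknown.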